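The compounds below may be only part of what the source reports. "The series", "measured", "known", "first", "only" and "open" are said of these compounds alone.

Working notes on the series. Compound 1 `COc1ccccc1S(=O)(=O)/C=C/c1ccccn1` and compound 2 `COc1ccc(S(=O)(=O)/C=C/c2ccccn2)cc1` share a sulfonyl-vinyl linkage carrying a pyridin-2-yl; the difference between the two cores is not broken down here. In an ADME assay on BV-2 cells (Mus musculus) for cytotoxicity, with a stated time of 24 h, tested at 50 uM (a lower number here means a stronger effect, a higher number a weaker effect of the compound at the concentration tested), compound 1 gives 100%, and compound 2 gives 100%, level with compound 1 at the digits printed; both stand together at the top of the three numbers. Compound 3 `COc1ccccc1S(=O)(=O)/C=C/c1cccnc1` carries the change pyridin-3-yl in place of pyridin-2-yl on a double-bonded chain carbon bound to a double-bonded chain carbon on the core of compound 1; in this assay compound 3 gives 92%, a step of a number 8 percentage points lower from compound 1 to compound 3 (within the scatter). Compound 4 `COc1ccc(S(=O)(=O)/C=C/c2cccnc2)cc1` applies the same change, (pyridin-3-yl in place of pyridin-2-yl on a double-bonded chain carbon bound to a double-bonded chain carbon), to the core of compound 2. For compound 4 the step is expected at about a number 5 percentage points lower from compound 2 to compound 4 (within the scatter) in this assay, resting on compound 1 to compound 3 with a number 8 percentage points lower from compound 1 to compound 3 (within the scatter). Compound 4 is therefore estimated at 95%, with a likely range from 82% to 105%.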

Compound 4, a percentage reported as activity, at one concentration (the size of the read-out at that concentration, not a potency): 85.8%
For compound 4 the middle estimate is 9.2 percentage points above the measured one; the range from low to high includes it.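

Pyridin-3-yl in place of pyridin-2-yl on a double-bonded chain carbon bound to a double-bonded chain carbon gives a number 14.2 percentage points lower from compound 2 to compound 4 (beyond the scatter) in this assay. Set beside the earlier step, the change carries from one core to the other with no difference that can be told apart: the same change on two cores in this assay, a number 8 percentage points lower (within the scatter) from compound 1 to compound 3 and a number 14.2 percentage points lower (beyond the scatter) from compound 2 to compound 4, 6.2 percentage points apart, within the scatter of two such steps. Within the data shown here, this rests on only two pairs, with the step within the scatter on one core and beyond it on the other, and it does not show that the step has a fixed size or would hold on a further core.

As far as these compounds go, what a phenyl or a pyridin-4-yl in that place would give in this assay remains open. So does the effect of an amine or a carboxylic acid on either core.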